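The source may hold more compounds than are shown below. What is called first, only, known or untested is meant among the compounds shown, and "the series" means these compounds.

In a functional assay on HeLa cells (Homo sapiens) for antiproliferative activity, read by CCK-8 assay, with a stated time of 72 h (on this read-out higher numbers stand for weaker inhibition and lower numbers for stronger inhibition), compound 3 `O=C(Nc1cccc(-c2oc3cc(-c4ccc(F)cc4)ccc3c(=O)c2O)c1)c1ccc(C(F)(F)F)cc1` gives 17400 nM, the highest of the three numbers measured. Compound 1 `O=C(Nc1cccc(-c2oc3cc(-c4ccc(F)cc4)ccc3c(=O)c2O)c1)c1ccc(Cl)cc1` gives 3670 nM, and compound 2 `COc1ccccc1C(=O)Nc1cccc(-c2oc3cc(-c4ccc(F)cc4)ccc3c(=O)c2O)c1` gives 14100 nM; the step from compound 2 to compound 3 is a 1.2-fold higher number from compound 2 to compound 3 (0.09 log units; within the scatter), while a 4.7-fold higher number from compound 1 to compound 3 (0.68 log units; beyond the scatter) and a 3.8-fold higher number from compound 1 to compound 2 (0.58 log units; beyond the scatter) both lie beyond the scatter.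

Compound 4 `O=C(Nc1cccc(-c2oc3cc(-c4ccc(F)cc4)ccc3c(=O)c2O)c1)c1ccc(Br)cc1` differs from compound 3 by bromo in place of trifluoromethyl on an aromatic carbon. Within the data shown here, the one measured step that bears directly on this position is a 4.7-fold higher number from compound 1 to compound 3 (0.68 log units; beyond the scatter), where the same aromatic carbon carried chloro instead of trifluoromethyl. Bromo, like chloro, is a single halogen atom on that carbon, so the change from compound 3 to compound 4 is expected to run the opposite way, towards a lower number, by roughly the size seen in compound 1, though a halogen swap of this kind is not itself represented among the measured pairs, so the uncertainty is wide. Compound 4 is therefore expected to give about 4500 nM in this assay, between 1800 nM and 12000 nM, an estimated step of a 3.9-fold lower number from compound 3 to compound 4 (0.59 log units; beyond the scatter).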

Compound 4, half-maximal inhibitory concentration: 9740 nM
Compound 4: the middle estimate sits 2.2-fold (0.34 log units) below what was measured; the measured number falls inside the stated range.
By their numbers in this assay, from the lowest: compound 1; then compounds 4, 2 and 3 (each within the scatter of the next).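

In this assay, a halogen on this aromatic carbon does not settle the number by itself, since a 2.7-fold higher number from compound 1 to compound 4 (0.42 log units; beyond the scatter) shows bromo and chloro parting beyond the scatter. By contrast, a 1.8-fold lower number from compound 3 to compound 4 (0.25 log units; within the scatter) and a 1.4-fold lower number from compound 2 to compound 4 (0.16 log units; within the scatter) both stay within it, so compound 4 groups with compound 2 and compound 3, and among these four compounds only compound 1, with its chloro group, stands apart. Nothing available here accounts for why chloro and bromo differ on this carbon.

The compounds shown leave open whether the result for compound 1 is particular to chloro or would also appear with fluoro, methyl or a nitrile on the same carbon. They also leave open whether an amine there would fall with compound 1 or with the other three.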